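A few compounds are considered here, and "the series" means these few. Any claim that something is new, unique, unknown or untested is made for them only; others in the source may bear on it.

Values in a functional assay on NALM-6 cells (Homo sapiens) for cytotoxicity, with a stated time of 72 h; on this read-out lower numbers stand for an effect already at smaller amounts and higher numbers for an effect only at larger amounts of compound:

- Compound 1 `C=C[C@@](C)(/C=C/c1ccc(OC)cc1)CCC=C(C)C`: > 43400 nM (a limit, not a number)
- Compound 2 `C=C[C@@](C)(/C=C/c1ccc(O)cc1)CCC1OC1(C)C`: > 43400 nM (a limit, not a number)
- Compound 3 `C=C[C@@](C)(/C=C/c1ccc(O)c(/C=C/C(=O)c2ccccc2)c1)CCC=C(C)C`: 4470 nM

Among the compounds with values here, compound 3 gives the only true number in this small set, 4470 nM. The other two results show (the limit of > 43400 nM in this assay, at which 2 of the 3 values shown sit).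

Compound 4 `C=C[C@@](C)(/C=C/c1ccc(O)c(/C=C/c2ccc(F)cc2)c1)CCC=C(C)C` keeps the shared core of compound 3 and alters one group: 4-fluorophenyl in place of benzoyl on a double-bonded chain carbon bound to a double-bonded chain carbon. In words, 4-fluorophenyl stands in place of benzoyl on a double-bonded chain carbon bound to a double-bonded chain carbon.

Within the data shown here, no measured pair here shows a swap of this kind, so the size of the step in this assay is a judgement. Compound 4 retains an aromatic ring on the added chain, a feature that compound 1 and compound 2 lack and that it shares with compound 3 at 4470 nM. Some measurable effect is therefore expected, though the benzoyl group is lost, so a modest move toward higher numbers seems more likely than a move in the opposite direction. The expected change is a 2.2-fold higher number from compound 3 to compound 4 (0.35 log units; beyond the scatter). For compound 4 the estimated value is 10000 nM, with an expected range from 3000 nM to 35000 nM.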

Compound 4, half-maximal effective concentration: > 43400 nM
Compound 4 was reported as a limit; the forecaster's own chance of this, stated with the estimate: 20%; at least 4.3-fold (0.63 log units) between middle value and limit.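

In this assay, putting 4-fluorophenyl in place of benzoyl on a double-bonded chain carbon bound to a double-bonded chain carbon gives an at least 9.7-fold higher number from compound 3 to compound 4 (0.98 log units; beyond the scatter), and this step is only a lower bound on the true change. Carrying an aromatic ring on the added chain is therefore not enough by itself: compound 4 has such a ring as well, yet among this pair a true number appears only for compound 3, at 4470 nM. Compound 4 gives > 43400 nM, which is a limit and not a number, and it joins the compounds at that same limit: the limit of > 43400 nM in this assay, at which 3 of the 4 values shown sit.

This swap removes the carbonyl and brings in a fluorine at the same time, and the compounds shown cannot say which of the two matters, a question that a plain phenyl or a 4-fluorobenzoyl at this place could help to separate. Also open, going by these compounds, is how far this assay tolerates other groups here, such as an amide or a carboxylic acid in place of benzoyl, and whether any of them would give a lower number than compound 3.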